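The compounds below may be only part of what the source reports. "The series", "measured", "known", "first", "only" and "open" are said of these compounds alone.

Compound 1 `CNC(=O)c1cc(C(=O)NC2CC2)cn(Cc2ccc(OC)cc2)c1=O` was studied in a physicochemical assay for solubility; on this read-out higher numbers stand for higher solubility and lower numbers for lower solubility. For compound 1 only a limit is reported in this assay, >= 143 ug/mL, which is the limit of >= 143 ug/mL in this assay, at which 1 of the 3 values shown sits. Two further compounds also give limits rather than numbers. Compound 2 `CCNC(=O)c1cc(C(=O)NC)c(=O)n(Cc2ccccc2)c1` reaches a limit in this assay of >= 144 ug/mL, which is the limit of >= 144 ug/mL in this assay, at which 1 of the 3 values shown sits. Compound 3 `CNC(=O)c1cc(C(=O)NC2CCC2)cn(Cc2ccccn2)c1=O` reaches a limit in this assay of >= 103 ug/mL, which is the limit of >= 103 ug/mL in this assay, at which 1 of the 3 values shown sits. All three measured compounds therefore sit at limits, and compound 1 cannot be ranked against the other two; the values show only that each reaches its own limit. Among the compounds with values here, no two measured compounds differ in a single place, so no measured step is available.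

Compound 4 `CNC(=O)c1cc(C(=O)NC2CC2)cn(Cc2cccc3cc[nH]c23)c1=O` has not yet been measured in this assay. It differs from compound 1 in one place: 1H-indol-7-yl in place of 4-methoxyphenyl on a saturated chain carbon bound to an aromatic nitrogen. The measured compounds give only limits, so no step size can be read from them, and the expected direction rests on the structural change alone. The step from compound 1 to compound 4 is expected to be a modest fall, an at least 1.5-fold lower number from compound 1 to compound 4 (0.20 log units; that floor lies within the scatter). Compound 4 is thus estimated to show 90 ug/mL in this assay, within a range from 30 ug/mL to 200 ug/mL.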

Compound 4, solubility: >= 144 ug/mL
Compound 4: a limit, no number (the forecaster's own chance of this, stated with the estimate: 35%); at least 1.6-fold (0.20 log units) between middle value and limit.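

Compound 1 and compound 4 both give only limits in this assay, not numbers, so the step between them cannot be read. The compounds shown leave open their actual solubility values, and so whether 1H-indol-7-yl in place of 4-methoxyphenyl changes solubility at all.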